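Adding a methyl group to compound 3

This account rests on a few compounds, and the source may have more. Where it says the series, first, only, none or still open, it means among the compounds named here.

Compound 1 `COc1ccccc1C(=O)/C=C/c1cc(=O)[nH]c(=O)n1COCCO`: 15200 nM
Compound 2 `COc1ccc(C(=O)/C=C/c2cc(=O)[nH]c(=O)n2COCCO)cc1`: 33500 nM
Compound 3 `O=C(/C=C/c1cc(=O)[nH]c(=O)n1COCCO)c1ccccc1`: 43300 nM

These numbers come from an ADME assay on L1210/0 cells (Mus musculus) for cytotoxicity, with a stated time of 48 h; on this read-out lower numbers stand for stronger inhibition and higher numbers for weaker inhibition. Compound 3 stands at the weak end of the set, a place it shares with compound 2: the record shows a 1.3-fold higher number from compound 2 to compound 3 (0.11 log units; within the scatter), and also a 2.8-fold higher number from compound 1 to compound 3 (0.45 log units; beyond the scatter). Compound 4 `Cc1ccc(C(=O)/C=C/c2cc(=O)[nH]c(=O)n2COCCO)cc1` has methyl in place of hydrogen on an aromatic carbon, para to a large group: methyl in place of hydrogen on an aromatic carbon. The closest comparison is the 4-methoxyphenyl group of compound 2, whose step to the unsubstituted phenyl stayed within the scatter. The larger step concerns the 2-methoxyphenyl group of compound 1, so it bears less on this change. No step beyond the scatter is therefore expected in this assay, and the estimate is a 1.2-fold lower number from compound 3 to compound 4 (0.08 log units; within the scatter). Compound 4 is expected at 36000 nM, with an estimated range of 17000 nM to 70000 nM.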

Compound 4, half-maximal inhibitory concentration: 27900 nM
Compound 4: the middle estimate sits 1.3-fold (0.11 log units) above what was measured; the range from low to high includes it.
By their numbers in this assay, from the lowest: compounds 1, 4, 2 and 3 (each within the scatter of the next, the first and the last beyond it).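

In this assay there is a 1.6-fold lower number from compound 3 to compound 4 (0.19 log units; within the scatter) for methyl in place of hydrogen, so a methyl on this aromatic carbon, para to a large group, gives no step beyond the scatter. Methyl and methoxy at this place cannot be told apart either, with a 1.2-fold lower number from compound 2 to compound 4 (0.08 log units; within the scatter) as their step, and a 1.8-fold higher number from compound 1 to compound 4 (0.26 log units; within the scatter) keeps the 4-methylphenyl group within the scatter of the 2-methoxyphenyl group. Nothing available explains these small steps. Still open, on these data alone, is whether an amine, a carboxylic acid or a longer chain at this place would give a step beyond the scatter.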